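The source may report more compounds than this note shows. Statements on the series, on what has been measured and on what is new or still open speak of the compounds shown alone.

Of the compounds shown here, three sharing one core have been measured in a functional assay for agonist activity at growth hormone secretagogue receptor type 1 (Homo sapiens), read by FLIPR; on this read-out lower numbers stand for smaller maximal responses and higher numbers for larger maximal responses. Compound 1 `C[C@@H]1CN(c2cccc(NS(=O)(=O)c3ccc(-c4ccccn4)s3)c2)C[C@H](C)N1` gives 0.8. Compound 2 `CCOc1ccc(N2C[C@@H](C)N[C@@H](C)C2)cc1NS(=O)(=O)c1ccc(-c2ccccn2)s1`, which carries an ethoxy group, gives 0.8. Compound 3 `CC(C)Oc1ccc(N2C[C@@H](C)N[C@@H](C)C2)cc1NS(=O)(=O)c1ccc(-c2ccccn2)s1`, which carries an isopropoxy group, gives 1.1 and stands highest of the three. Between the first two there is no change at the digits printed from compound 1 to compound 2 (within the scatter). Adding the isopropoxy group brings a number 0.30 higher from compound 1 to compound 3 (beyond the scatter), and lengthening the ethoxy group into it brings a number 0.30 higher from compound 2 to compound 3 (beyond the scatter).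

Compound 4 `C[C@@H]1CN(c2ccc(Cl)c(NS(=O)(=O)c3ccc(-c4ccccn4)s3)c2)C[C@H](C)N1` differs from compound 3 in one place: chloro in place of isopropoxy on an aromatic carbon. The chloro group sits ortho to a large group and para to the 3,5-dimethylpiperazin-1-yl group. Within the data shown here, no measured step involves a chloro group at this position, so the only guide is that compound 1, with hydrogen there, and compound 2, with ethoxy there, sit at the same level, while only the isopropoxy group of compound 3 lifted the response. The chloro group is a single heavy atom, closer in size to the hydrogen of compound 1 than to isopropoxy, so compound 4 is expected to fall back toward that level, a step of a number 0.25 lower from compound 3 to compound 4 (beyond the scatter). Compound 4 is therefore estimated at 0.85, within a range from 0.65 to 1.05.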

Compound 4, intrinsic activity: the largest response reached, as a fraction of the reference agonist's: 1
Estimate against measurement, compound 4: 0.15 below, within the range that was stated.
By their numbers in this assay, from the lowest: compounds 1 and 2 (each within the scatter of the next); then compounds 4 and 3 (each within the scatter of the next).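

In this assay, among these compounds, isopropoxy turns out not to be the only group at this position that goes with a larger maximal response: replacing it with chloro gives a number 0.10 lower from compound 3 to compound 4 (within the scatter) and so leaves the two groups indistinguishable. Chloro also separates from the other two groups, with a number 0.20 higher from compound 2 to compound 4 (beyond the scatter) when it replaces ethoxy and a number 0.20 higher from compound 1 to compound 4 (beyond the scatter) when it replaces hydrogen, so a single heavy atom is enough here, and ethoxy, level with hydrogen, goes against any simple rise with group size. Nothing available explains why these groups differ.

The compounds shown leave open how a fluoro, a methyl, an amine or a carboxylic acid would read at this position. They also leave open whether a longer chain joined through oxygen would match isopropoxy or fall back to the level of ethoxy.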